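The compounds below may be only part of what the source reports. "The series", "measured", "known", "first", "only" and "open" are said of these compounds alone.

Compound 1 `C/C(=N\NC(=S)Nc1ccccc1I)c1ccccn1`: 6.1 nM
Compound 2 `C/C(=N\NC(=S)Nc1ccc(Cl)cc1)c1ccccn1`: 1.7 nM
Compound 3 `C/C(=N/NC(=S)Nc1ccccc1I)c1ccccn1`: 6.1 nM

In a functional assay on U-87MG ATCC cells (Homo sapiens) for cytotoxicity, read by MTT assay, with a stated time of 48 h (on this read-out lower numbers stand for stronger inhibition and higher numbers for weaker inhibition), compound 1 gives 6.1 nM, level with compound 3 at 6.1 nM, and these two share the highest number of the set. The lowest number belongs to compound 2 at 1.7 nM, a clear gap from compound 1.

The next step leads to compound 4 `C/C(=N\NC(=S)Nc1ccccc1[N+](=O)[O-])c1ccccn1`, which has nitro in place of iodo on an aromatic carbon, ortho to a large group: nitro in place of iodo on an aromatic carbon.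

Within the data shown here, only one step has been measured between closely matched compounds, no change at the digits printed from compound 1 to compound 3 (within the scatter). It rests on (the fact that compounds 1 and 3 differ only in the configuration as drawn), so it leaves the iodo group untouched and says nothing direct about this swap. Among the measured compounds shown here, compound 2, at 1.7 nM, shows only that numbers in this set have so far stayed within a narrow low range. No direction can therefore be argued, and no step beyond the scatter is firmly expected.

The expected step is a 1.2-fold lower number from compound 1 to compound 4 (0.09 log units; within the scatter). For compound 4 the estimated value is 5 nM, with an expected range of 1.5 nM to 20 nM.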

Compound 4, half-maximal inhibitory concentration: 4.3 nM
The estimate for compound 4 lay 1.2-fold (0.07 log units) above the measured number, within the range that was stated.
By their numbers in this assay, from the lowest: compound 2; then compounds 4, 1 and 3 (each within the scatter of the next).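

In this assay nitro in place of iodo on an aromatic carbon, ortho to a large group, gives a 1.4-fold lower number from compound 1 to compound 4 (0.15 log units; within the scatter) and so leaves the number essentially unchanged. The earlier step altered only the configuration as drawn, whereas this one shows that the substituent itself can be exchanged: a single iodine gives way to a group of 3 heavy atoms with 2 hydrogen-bond acceptors, with no change beyond the scatter. Nothing shown here explains why these two groups read alike.

Going by these compounds, whether an amine, a carboxylic acid or a longer chain on this same carbon would also stay level remains open. Also open, on these data alone, is whether nitro would give a similar number on another carbon of the same ring.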